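Notes on cyclopentylamino to methylamino

A few compounds are considered here, and "the series" means these few. Any claim that something is new, unique, unknown or untested is made for them only; others in the source may bear on it.

Measured so far in a functional assay on DU-145 cells (Homo sapiens) for antiproliferative activity, read by sulforhodamine B assay, with a stated time of 48 h; on this read-out lower numbers stand for stronger inhibition of growth and higher numbers for weaker inhibition of growth
- compound 1 `COc1ccc(Nc2nc(NC3CCCC3)c3ccccc3n2)cc1` gives 12400 nM
- compound 2 `COc1ccc(N(C)c2nc(NC3CCCC3)c3ccccc3n2)cc1` gives 10200 nM

Going by the values given here, compound 2 stands at 10200 nM and sits level with the only other measured compound. Among the compounds with values here, the single measured step is a 1.2-fold lower number from compound 1 to compound 2 (0.08 log units; within the scatter) and it lies at a different place in the structure. Within the data shown here, compound 3 `CNc1nc(N(C)c2ccc(OC)cc2)nc2ccccc12` has methyl in place of cyclopentyl on a nitrogen on an aromatic ring and no measured step covers that change. With no measured guide, no shift beyond the scatter is expected, and the estimated step is a 1.2-fold higher number from compound 2 to compound 3 (0.07 log units; within the scatter) with wide uncertainty. For compound 3 the expected value is 12000 nM within an estimated range from 3000 nM to 40000 nM in this assay for now.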

Compound 3, concentration for 50% growth inhibition: 24300 nM
For compound 3 the middle estimate is 2.0-fold (0.31 log units) below the measured one; the range from low to high includes it.
By their numbers in this assay, from the lowest: compounds 2, 1 and 3 (each within the scatter of the next, the first and the last beyond it).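

Methyl in place of cyclopentyl on a nitrogen on an aromatic ring gives a 2.4-fold higher number from compound 2 to compound 3 (0.38 log units; beyond the scatter) in this assay and is the first step in the series to pass the scatter. This position therefore shows some dependence on its group, though the step is modest and rests on one pair. No evidence bears on the origin of this shift.

On these data alone, whether ethyl, cyclohexyl or a longer chain on this nitrogen would keep the value of compound 2 remains open. Also open, as far as these compounds go, is whether the same change behaves alike with hydrogen on the other nitrogen, as in compound 1.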